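Methoxy for fluoro on the anilide of compound 3

A few compounds are considered here, and "the series" means these few. Any claim that something is new, unique, unknown or untested is made for them only; others in the source may bear on it.

Three compounds have been measured in a functional assay on HOS cells (Homo sapiens) for inhibition, read by MTT assay, with a stated time of 72 h; a higher number here means a weaker inhibitor, a lower number a stronger inhibitor:
compound 1, `O=C(CCC(=O)OCCCCCCSc1ccc([N+](=O)[O-])c2nonc12)Nc1ccccc1`, gives 2120 nM;
compound 2, `COc1ccccc1NC(=O)CCC(=O)OCCCCCCSc1ccc([N+](=O)[O-])c2nonc12`, gives 2850 nM;
compound 3, `O=C(CCC(=O)OCCCCCCSc1ccc([N+](=O)[O-])c2nonc12)Nc1ccc(F)cc1`, gives 2080 nM.

Compound 3 has the lowest of the three numbers, but its neighbours sit close: the step of a 1.0-fold lower number from compound 1 to compound 3 (0.01 log units; within the scatter) and the step of a 1.4-fold lower number from compound 2 to compound 3 (0.14 log units; within the scatter) both lie within the scatter, so no order among the three can be read from these values.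

Compound 4, `COc1ccc(NC(=O)CCC(=O)OCCCCCCSc2ccc([N+](=O)[O-])c3nonc23)cc1`, differs from compound 3 by methoxy in place of fluoro on an aromatic carbon. For the measured compounds named here, three measured steps bear on this change. Methoxy in place of hydrogen gave a 1.3-fold higher number from compound 1 to compound 2 (0.13 log units; within the scatter), fluoro in place of hydrogen gave a 1.0-fold lower number from compound 1 to compound 3 (0.01 log units; within the scatter), and the exchange of the whole anilide group gave a 1.4-fold lower number from compound 2 to compound 3 (0.14 log units; within the scatter). None of them moved the number beyond the scatter. The change to compound 4 is therefore expected to give no step beyond the scatter, a 1.1-fold higher number from compound 3 to compound 4 (0.04 log units; within the scatter). Compound 4 is estimated at 2300 nM, with a range from 1200 nM to 4500 nM.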

Compound 4, half-maximal inhibitory concentration: 1800 nM
Estimate against measurement, compound 4: 1.3-fold (0.11 log units) above; measured number inside the range.
By their numbers in this assay, from the lowest: compounds 4, 3, 1 and 2 (each within the scatter of the next).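

In this assay, fluoro and methoxy on this aromatic carbon, para to a large group, are not told apart: the exchange gives a 1.2-fold lower number from compound 3 to compound 4 (0.06 log units; within the scatter). The same holds for methoxy in place of hydrogen at this position, with a 1.2-fold lower number from compound 1 to compound 4 (0.07 log units; within the scatter), and for the 4-methoxyphenyl group in place of the 2-methoxyphenyl group, with a 1.6-fold lower number from compound 2 to compound 4 (0.20 log units; within the scatter), so neither the presence of the methoxy nor the choice between these two placements separates these compounds. Nothing at hand speaks to why these steps stay so small.

The anilides shown carry only hydrogen, fluoro or methoxy, so it remains open whether an amine or a carboxylic acid at this position would move the number beyond the scatter. Going by these compounds, whether a longer chain in place of the one shared by all four compounds would do so is equally open.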